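Bromo for methyl on two cores of the series

This account rests on a few compounds, and the source may have more. Where it says the series, first, only, none or still open, it means among the compounds named here.

Compound 1 `CCO[C@H]1C[C@@H](c2coc3ccc(C)cc3c2=O)N(c2ccccc2)O1` carries an ethoxy-substituted isoxazolidine core. In a functional assay on PC-3 cells (Homo sapiens) for inhibition, read by sulforhodamine B assay, with a stated time of 48 h (on this read-out higher numbers stand for weaker inhibition and lower numbers for stronger inhibition), compound 1 gives 39000 nM. Compound 2 `Cc1ccc2occ([C@@H]3[C@H]4C(=O)N(c5ccccc5)C(=O)[C@H]4ON3c3ccccc3)c(=O)c2c1` and compound 3 `O=C1[C@H]2[C@H](ON(c3ccccc3)[C@@H]2c2coc3ccc(Br)cc3c2=O)C(=O)N1c1ccccc1` share a different, fused bicyclic core; the difference between the two cores is not broken down here. In this assay compound 2 gives 11100 nM, and compound 3 gives 13300 nM. The step of a 1.2-fold higher number from compound 2 to compound 3 (0.08 log units; within the scatter) follows the change (bromo in place of methyl on an aromatic carbon). Compound 1 stands apart from both, with its number beyond the scatter relative to compound 2 and compound 3.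

Compound 4 `CCO[C@H]1C[C@@H](c2coc3ccc(Br)cc3c2=O)N(c2ccccc2)O1` has not yet been measured in this assay. It differs from compound 1 by bromo in place of methyl on an aromatic carbon, the same change as that from compound 2 to compound 3, set on the same kind of position in both cases. For the measured compounds named here, with only one measured instance of this change, the expectation for compound 4 rests on that single pair: a step of about a 1.2-fold higher number from compound 1 to compound 4 (0.08 log units; within the scatter) is expected from compound 1 to compound 4, matching in size the measured step of a 1.2-fold higher number from compound 2 to compound 3 (0.08 log units; within the scatter). On this basis compound 4 is estimated at 47000 nM in this assay, with a likely range from 20000 nM to 110000 nM. The starting number of compound 1, at 39000 nM, is already the highest of the three measured here.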

Compound 4, half-maximal inhibitory concentration: > 60000 nM
Compound 4: no number, only a limit; the forecaster's own chance of this, stated with the estimate: 20%; middle value at least 1.2-fold (0.10 log units) away from the limit.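

In this assay compound 4 gives only a limit of the assay, not a number: the limit of > 60000 nM in this assay, at which 1 of the 4 values shown sits.

Bromo in place of methyl on an aromatic carbon gives an at least 1.5-fold higher number from compound 1 to compound 4 (0.18 log units; that floor lies within the scatter), so on neither core does this change bring a lower number beyond the scatter. The notes do not show that the change carries from one core to the other with the same size, since the true size of the step on the core of compound 1 is unknown: the same change on two cores in this assay, a 1.2-fold higher number (0.08 log units; within the scatter) from compound 2 to compound 3 and an at least 1.5-fold higher number (0.18 log units; that floor lies within the scatter) from compound 1 to compound 4; the limit leaves it open whether they differ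

The compounds shown leave open how other groups on this aromatic carbon would read on either core, for instance chloro, an amine or a carboxylic acid. They also leave open what a longer chain in place of the ethoxy group would do on the core of compound 1.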